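Removing a hydroxy next to the acid amide

The compounds below may be only part of what the source reports. "The series", "measured", "known", "first", "only" and "open" are said of these compounds alone.

Compound 1 `C=C(CC)C(=O)c1ccc(OCC(=O)Nc2nc3ccccc3s2)c(Cl)c1Cl` gives 1500 nM in a functional assay on CLL cells (Homo sapiens) for cytotoxicity, read by MTT assay, with a stated time of 48 h; a higher number here means that more compound is needed for the effect, a lower number that less compound is needed.
Compound 2 `C=C(CC)C(=O)c1ccc(OCC(=O)NCCO)c(Cl)c1Cl` gives > 25000 nM in this assay, which is a limit of the assay and not a number.
Compound 3 `C=C(CC)C(=O)c1ccc(OCC(=O)Nc2ccc(C(=O)O)c(O)c2)c(Cl)c1Cl` gives > 25000 nM in this assay, again a limit of the assay rather than a number.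

Compound 3 therefore stands at the limit, and the limit of > 25000 nM in this assay, at which 2 of the 3 values shown sit, shows that it shares this position with compound 2. Compound 4 `C=C(CC)C(=O)c1ccc(OCC(=O)Nc2ccc(C(=O)O)cc2)c(Cl)c1Cl` is the compound still to be measured; it differs from compound 3 in one place, (hydrogen in place of hydroxy on an aromatic carbon). Going by the values given here, only one measured step exists in this set, an at least 16-fold higher number from compound 1 to compound 2 (1.22 log units; beyond the scatter), and that step changes the whole group on the amide-type nitrogen, not a single substituent on an aromatic ring; it bears on the present change only in showing that an amide substituent without the benzothiazole can push a compound to the limit. Since compound 3 itself sits at the limit, the step is expected to be none beyond the scatter, a number no higher from compound 3 to compound 4 (the limit leaves the size open). Compound 4 is therefore estimated at 25000 nM, in the range from 8000 nM to 60000 nM, with a limit again the most likely outcome.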

Compound 4, half-maximal effective concentration: 5000 nM
Compound 4: middle estimate off by 5.0-fold (0.70 log units), on the high side; measured number below the stated range.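

Removing the hydroxy ortho to the carboxy group is enough to bring the compound off the limit in this assay, with an at least 5.0-fold lower number from compound 3 to compound 4 (0.69 log units; beyond the scatter). So this place on the ring matters, and an amide substituent without the 1,3-benzothiazol-2-yl group need not end at the limit: 4-carboxyphenyl gives an at least 5.0-fold lower number from compound 2 to compound 4 (0.69 log units; beyond the scatter). Even so, it does not match the 1,3-benzothiazol-2-yl group, with a 3.3-fold higher number from compound 1 to compound 4 (0.52 log units; beyond the scatter).

The real size of the step from the hydroxy to hydrogen stays open, as compound 3 has only a limit and not a number: the limit of > 25000 nM in this assay, at which 2 of the 4 values shown sit. Nor do the compounds shown tell whether a methoxy group or an amine ortho to the carboxy group would behave like hydrogen or like hydroxy.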